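Swapping the 4-acetoxyphenyl group of compound 2

The compounds below may be only part of what the source reports. "The series", "measured", "known", "first", "only" and "open" are said of these compounds alone.

Compound 1 `Cc1ccc(S(=O)(=O)/C(=C/c2ccc(N(C)C)cc2)C(=O)c2ccc(Cl)cc2)cc1`: > 100000 nM (a limit)
Compound 2 `CC(=O)Oc1ccc(/C=C(\C(=O)c2ccc(Cl)cc2)S(=O)(=O)c2ccc(C)cc2)cc1`: 25000 nM

For the measured compounds named here, in a functional assay on DU-145 cells (Homo sapiens) for inhibition, read by trypan blue exclusion, with a stated time of 96 h (a lower number here means a stronger inhibitor of growth, a higher number a weaker inhibitor of growth), compound 2 gives 25000 nM, the only actual number so far. The value of compound 1 is a limit. Compound 3 `Cc1ccc(S(=O)(=O)/C(=C/c2ccccc2F)C(=O)c2ccc(Cl)cc2)cc1` carries 2-fluorophenyl in place of 4-acetoxyphenyl on a double-bonded chain carbon bound to a double-bonded chain carbon. Going by the values given here, the one measured step, an at least 4.0-fold lower number from compound 1 to compound 2 (0.60 log units; beyond the scatter), changed a group on that same aromatic ring, but it gives no direction for this swap. No change beyond the scatter is therefore expected in this assay. The expected step is a 1.3-fold lower number from compound 2 to compound 3 (0.10 log units; within the scatter). Compound 3 is estimated at 20000 nM, with an expected range of 5000 nM to 80000 nM.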

Compound 3, concentration for 50% growth inhibition: 2500 nM
Estimate against measurement, compound 3: 8.0-fold (0.90 log units) above; the measured number lies below the stated range.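

In this assay, the place on a double-bonded chain carbon bound to a double-bonded chain carbon responds strongly to a change of the whole aryl group: 2-fluorophenyl in place of 4-acetoxyphenyl gives a 10-fold lower number from compound 2 to compound 3 (1.00 log units; beyond the scatter). In place of 4-(dimethylamino)phenyl, it gives an at least 40-fold lower number from compound 1 to compound 3 (1.60 log units; beyond the scatter). Compound 1 stands at a limit, so that step is a bound only: the limit of > 100000 nM in this assay, at which 1 of the 3 values shown sits.

The compounds shown leave open whether the fluorine itself matters or only the loss of the acetoxy group. An unsubstituted phenyl, or a chlorine or methoxy group on this ring, would separate the two.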